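The source may report more compounds than this note shows. Statements on the series, on what has been measured and on what is new or still open speak of the compounds shown alone.

Compound 1 `Cc1cccc(NC(=O)CSc2snnc2-c2ccc(Br)cc2Br)c1C` is the starting point. In an ADME assay on MT4 cells (Homo sapiens) for cytotoxicity, read by MTT assay, with a stated time of 5 days (a higher number here means that more compound is tolerated, a lower number that less compound is tolerated), compound 1 gives 241000 nM, the highest of the two plain numbers seen so far. Compound 2 `O=C(CSc1snnc1-c1ccc(Br)cc1Br)Nc1ccccn1` gives 42400 nM in this assay, a step of a 5.7-fold lower number from compound 1 to compound 2 (0.75 log units; beyond the scatter). Compound 3 `COC(=O)c1ccsc1NC(=O)CSc1snnc1-c1ccc(Br)cc1Br` reaches only a limit of the measurement in this assay, not a number: > 227000 nM (the limit of > 227000 nM in this assay, at which 1 of the 3 values shown sits). The step from compound 1 to compound 3 is therefore unreadable a step that the limit leaves unreadable from compound 1 to compound 3, while the number rises from compound 2 to compound 3 an at least 5.3-fold higher number from compound 2 to compound 3 (0.72 log units; beyond the scatter). Compound 4 `O=C(CSc1snnc1-c1ccc(Br)cc1Br)Nc1nccs1` has not yet been measured; its change from compound 1 is 1,3-thiazol-2-yl in place of 2,3-dimethylphenyl on an amide-type nitrogen. The step of a 5.7-fold lower number from compound 1 to compound 2 (0.75 log units; beyond the scatter) is the closest guide, since another small nitrogen-containing ring enters at the same place, so a modest fall is expected a 3.0-fold lower number from compound 1 to compound 4 (0.48 log units; beyond the scatter). Compound 4 is thus estimated at 80000 nM, between 30000 nM and 230000 nM.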

Compound 4, half-maximal cytotoxic concentration: 87800 nM
Beside the measured number, compound 4's estimate is 1.1-fold (0.04 log units) below it; measured number inside the range.
By their numbers in this assay, from the lowest: compound 2; then compound 4; then compound 1.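

Putting 1,3-thiazol-2-yl on the amide-type nitrogen gives a 2.7-fold lower number from compound 1 to compound 4 (0.44 log units; beyond the scatter), so pyridin-2-yl is not the only small ring in this place that lowers the number. The two small rings are also not equal, with a 2.1-fold higher number from compound 2 to compound 4 (0.32 log units; beyond the scatter), and 1,3-thiazol-2-yl in place of 3-(methoxycarbonyl)thiophen-2-yl gives an at least 2.5-fold lower number from compound 3 to compound 4 (0.41 log units; beyond the scatter). For compound 3 that step rests on a limit of the measurement, not a number: the limit of > 227000 nM in this assay, at which 1 of the 4 values shown sits.

Plain phenyl in this place remains open, so the fall cannot yet be separated into loss of the two methyl groups and entry of ring nitrogen. Going by these compounds, how an amine or a carboxylic acid on 1,3-thiazol-2-yl would move the number is also open.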